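The compounds below may be only part of what the source reports. "The series", "measured", "known", "first", "only" and "open" are said of these compounds alone.

Compound 1 `CCOC(=O)C1=C(Nc2ccccc2Br)S/C(=C\c2ccc[nH]2)C1=O`: 36300 nM
Compound 2 `CCOC(=O)C1=C(Nc2ccc([N+](=O)[O-])cc2)S/C(=C\c2ccc[nH]2)C1=O`: > 100000 nM

In a functional assay on K562 cells (Homo sapiens) for inhibition, read by MTT assay, with a stated time of 72 h (a higher number here means a weaker inhibitor, a lower number a stronger inhibitor), compound 2 reaches only the limit of the assay, > 100000 nM, so no number is known for it. In this assay compound 1 gives 36300 nM. Within the data shown here, the only measured step, an at least 2.7-fold higher number from compound 1 to compound 2 (0.44 log units; beyond the scatter), bears on the new one, and it rests on (the limit of > 100000 nM in this assay, at which 1 of the 2 values shown sits). Compound 3 `CCOC(=O)C1=C(Nc2cccc([N+](=O)[O-])c2)S/C(=C\c2ccc[nH]2)C1=O` differs from compound 2 by 3-nitrophenyl in place of 4-nitrophenyl on an amine nitrogen. Among the measured compounds shown here, since no measured step compares two nitrophenyl groups, the step of a number no higher from compound 2 to compound 3 (the limit leaves the size open) is expected to stay within the scatter. Compound 3 is therefore estimated at 100000 nM, with a range from 30000 nM to 300000 nM, and a limit again seems likely.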

Compound 3, half-maximal inhibitory concentration: 7200 nM
Estimate against measurement, compound 3: 14-fold (1.14 log units) above; the whole stated range lies above it.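

Swapping 4-nitrophenyl for 3-nitrophenyl on the amine nitrogen keeps the same atoms, yet this assay shows an at least 13-fold lower number from compound 2 to compound 3 (1.14 log units; beyond the scatter), so the arrangement within this group matters and not just its composition. Going by these compounds, compound 2 stands at a limit, not a number, so the true size of that step stays open: the limit of > 100000 nM in this assay, at which 1 of the 3 values shown sits. 3-Nitrophenyl also outperforms 2-bromophenyl, with a 5.0-fold lower number from compound 1 to compound 3 (0.70 log units; beyond the scatter). On these data alone, what remains open is how 3-aminophenyl or 3-methoxyphenyl would compare on the same nitrogen, and whether 3-bromophenyl would follow compound 3.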